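The compounds below may be only part of what the source reports. "The series", "measured", "known", "first", "only" and "open" are said of these compounds alone.

Of the compounds shown here, three built on the same core have been tested in an ADME assay on Karpas-1106P cells (Homo sapiens) for cytotoxicity (on this read-out lower numbers stand for an effect already at smaller amounts and higher numbers for an effect only at larger amounts of compound), so far, and they differ only in the group on a carbonyl carbon: compound 1 (`Cc1ccc(S(=O)(=O)N[C@@H](CC(=O)NC(C)(C)C)C(=O)NCCNC(=O)Nc2ccccc2)cc1`), compound 2 (`Cc1ccc(S(=O)(=O)N[C@@H](CC(=O)NC(C)(C)C)C(=O)NCCNC(=O)c2cc(Cl)ccc2Cl)cc1`) and compound 3 (`C#Cc1cccc(C(=O)NCCNC(=O)[C@H](CC(=O)NC(C)(C)C)NS(=O)(=O)c2ccc(C)cc2)c1`). Compound 1 gives > 11100 nM as a limit of the assay, not a number. Compound 2 gives > 11100 nM as a limit too. Compound 3 gives > 11100 nM as a limit as well. Compound 3 therefore has no exact place in the series (the limit of > 11100 nM in this assay, at which 3 of the 3 values shown sit).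

Compound 4 (`Cc1ccc(S(=O)(=O)N[C@@H](CC(=O)NC(C)(C)C)C(=O)NCCNC(=O)c2cccc(C(F)(F)F)c2)cc1`) keeps all of compound 3 except one group, with trifluoromethyl in place of ethynyl on an aromatic carbon, meta to a large group (trifluoromethyl in place of ethynyl on an aromatic carbon). The measured steps that bear on this are swaps on the carbonyl carbon rather than on the ring itself: there is a step that the two limits leave unreadable from compound 1 to compound 2 and also a step that the two limits leave unreadable from compound 1 to compound 3 in this set. The nearest of them for compound 3 is a step that the two limits leave unreadable from compound 2 to compound 3 and, like the others, it gives no size to carry over. All that can be said is that each of these groups left the read-out at the limit. The expected outcome is therefore a number no higher from compound 3 to compound 4 (the limit leaves the size open) with no move in either direction beyond the scatter. The estimate for compound 4 is 11100 nM in an expected range from 5000 nM to 25000 nM and it will probably be reported as a limit again.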

Compound 4, half-maximal effective concentration: > 11100 nM
Compound 4: a limit, no number; the forecaster's own chance of this, stated with the estimate: 90%; the middle value sits exactly at the limit.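

Compound 4 also ends at a limit, so no step from compound 1, compound 2 or compound 3 to compound 4 can be read in this assay, and the picture stays as it was: the limit of > 11100 nM in this assay, at which 4 of the 4 values shown sit.

The compounds shown leave open what size of effect, if any, separates these groups on the carbonyl carbon, and at what concentration any of the four compounds would give a measurable effect on these cells.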